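The source may hold more compounds than are shown below. What is called first, only, known or untested is meant among the compounds shown, and "the series" means these compounds.

Compounds measured in a functional assay on the whole organism (Tail, strain ICR) with Mus musculus as the target, in the tail flick test, with a stated time of 120 min, at a dose of 25 umol/kg by the oral route; a higher number here means a stronger effect of the compound at the dose given, a lower number a weaker effect:
Compound 1 `CC[C@H](C)[C@H](NC(=O)CN(c1nc(Cl)nc2[nH]cnc12)C1CC1)C(=O)O` gives 21.4%.
Compound 2 `O=C(CN(c1nc(Cl)nc2[nH]cnc12)C1CC1)N[C@@H](CC(=O)OCc1ccccc1)C(=O)OCc1ccccc1` gives 12.1%.
Compound 3 `O=C(O)CC[C@H](NC(=O)CN(c1nc(Cl)nc2[nH]cnc12)C1CC1)C(=O)O` gives 30.1%.

Compound 2 stands lowest of the three; its gap to compound 1 lies within the scatter, its gap to compound 3 beyond it. Compound 4 `CC(C)C[C@H](NC(=O)CN(c1nc(Cl)nc2[nH]cnc12)C1CC1)C(=O)OCc1ccccc1` differs from compound 2 as follows: isopropyl in place of benzyloxycarbonyl on a saturated chain carbon, two bonds along the chain from an amide-type nitrogen and a carbonyl carbon. For the measured compounds named here, the only measured step, a number 8.7 percentage points higher from compound 1 to compound 3 (within the scatter), alters the side chain at a neighbouring place and stays within the scatter, so the data offer no sign that a side-chain change of this kind moves this assay much. The step of a number 5.9 percentage points higher from compound 2 to compound 4 (within the scatter) is therefore expected to stay within the scatter. Compound 4 is estimated at 18%, between 7% and 30%.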

Compound 4, a percentage reported as activity, at one dose (the size of the read-out at that dose, not a potency): 8.58%
Estimate against measurement, compound 4: 9.4 percentage points above; the range from low to high includes it.
By their numbers in this assay, from the lowest: compounds 4, 2, 1 and 3 (each within the scatter of the next, the first and the last beyond it).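

In this assay the exchange of benzyloxycarbonyl for isopropyl, on a saturated chain carbon two bonds along the chain from an amide-type nitrogen and a carbonyl carbon, gives a number 3.5 percentage points lower from compound 2 to compound 4 (within the scatter), the first step read directly at this position. Replacing the 10 heavy atoms and the six-membered aromatic ring of benzyloxycarbonyl with the 3 carbons of isopropyl thus leaves no readable difference at this dose. Nothing available accounts for this result. Still open, from the compounds shown here alone, is whether an amine, a carboxylic acid or a longer chain at this place would give a step beyond the scatter.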